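A few compounds are considered here, and "the series" means these few. Any claim that something is new, unique, unknown or untested is made for them only; others in the source may bear on it.

In a functional assay on NCI/ADR-RES cells (Homo sapiens) for inhibition, read by spectrophotometry and sulforhodamine B assay, with a stated time of 48 h (a higher number here means a weaker inhibitor of growth, a lower number a stronger inhibitor of growth), compound 1 (`O=C1CS/C(=N/N=C/c2c[nH]c3ccccc23)N1c1cccc2ccccc12`) gives 38600 nM as the higher of the two numbers in hand. Compound 2 (`Cc1ccc(NC(=S)N/N=C/c2c[nH]c3ccccc23)cc1`) gives 1460 nM and sits lower, beyond the scatter. Compound 3 (`O=C1CS/C(=N/N=C/c2c[nH]c3ccc(Br)cc23)N1c1cccc2ccccc12`) differs from compound 1 by bromo in place of hydrogen on an aromatic carbon. Going by the values given here, no measured pair shows this change, so only a modest step toward a lower number in this assay is expected, possibly none beyond the scatter. The estimated move is a 1.9-fold lower number from compound 1 to compound 3 (0.29 log units; within the scatter) at the middle of the range. In this assay the expected value for compound 3 is 20000 nM with 6000 nM to 60000 nM as the estimated range.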

Compound 3, concentration for 50% growth inhibition: 12400 nM
Estimate against measurement, compound 3: 1.6-fold (0.21 log units) above; the range from low to high includes it.
By their numbers in this assay, from the lowest: compound 2; then compound 3; then compound 1.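

Going by these compounds alone, on the six-membered aromatic ring of carbon only, at the carbon meta to a fused ring and para to a fused ring, bromo in place of hydrogen gives in this assay a 3.1-fold lower number from compound 1 to compound 3 (0.49 log units; beyond the scatter) and so shows that this position can shift growth inhibition, which the earlier compounds could not show. No measurement in hand gives a reason for this step. Going by these compounds, whether the step is specific to bromo remains open, as chloro, methoxy or an amine on the same carbon would show. On these data alone, whether the same change would carry over to compound 2 also remains open.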